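The compounds below may be only part of what the source reports. "The series", "measured", "known", "first", "only" and "open" are said of these compounds alone.

Values in a functional assay on the whole organism (Abdomen) with Mus musculus as the target; a higher number here means that more compound is needed for the effect, a lower number that less compound is needed:
- compound 1 `CCc1nc(Cc2c[nH]cn2)c(CC)s1`: 1.8 mg/kg
- compound 2 `CCCCc1nc(Cc2c[nH]cn2)c(CCCC)s1`: > 30 mg/kg, a limit of the assay
- compound 3 `CCc1sc(C)nc1Cc1c[nH]cn1`: 2.3 mg/kg
- compound 4 `CCc1nc(Cc2c[nH]cn2)c(C(C)C)s1`: not yet measured

Compound 1 stands level with its nearest measured neighbour: a 1.3-fold higher number from compound 1 to compound 3 (0.11 log units; within the scatter). Compound 4 differs from compound 1 by one change, ethyl to isopropyl: methyl in place of hydrogen on a saturated chain carbon bound to an aromatic carbon and a saturated chain carbon. For the measured compounds named here, the only measured one-place step, quoted above, also concerns a single methyl on a chain and stays within the scatter. Compound 2, with butyl chains, gives only a limit, > 30 mg/kg, and on that limit a modest move to a higher number is expected in this assay for compound 4. The expected step is a 1.7-fold higher number from compound 1 to compound 4 (0.22 log units; within the scatter), close to the scatter. Compound 4 is estimated at 3 mg/kg, with an expected range of 1.2 mg/kg to 10 mg/kg.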

Compound 4, dose for half-maximal effect: 25.3 mg/kg
Compound 4: the middle estimate sits 8.4-fold (0.93 log units) below what was measured; measured number outside the range, above it.
By their numbers in this assay, from the lowest: compounds 1 and 3 (each within the scatter of the next); then compound 4. At a limit, above all of these: compound 2.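

Going from ethyl to isopropyl gives, in this assay, a 14-fold higher number from compound 1 to compound 4 (1.15 log units; beyond the scatter), so one methyl on a saturated chain carbon bound to an aromatic carbon and a saturated chain carbon is enough to produce a large step. The single-methyl step on the other chain, a 1.3-fold higher number from compound 1 to compound 3 (0.11 log units; within the scatter), stays within the scatter, so a methyl change does not carry the same weight at both chains. Compound 4 still gives a number, but the ceiling of the assay is close: the limit of > 30 mg/kg in this assay, at which 1 of the 4 values shown sits.

What lies behind the step remains open. Also open, as far as these compounds go, is how a cyclopropyl, a tert-butyl or a hydroxymethyl group would read at this position.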